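A few compounds are considered here, and "the series" means these few. Any claim that something is new, unique, unknown or untested is made for them only; others in the source may bear on it.

Measured so far in an ADME assay on the whole organism (Rattus norvegicus, strain Sprague-Dawley) for pharmacokinetics, read by LC-MS, at a dose of 10 mg/kg by the oral route; on this read-out lower numbers stand for lower oral bioavailability and higher numbers for higher oral bioavailability:
- compound 1 `CCOC(=O)[C@H](F)ON1C(=O)N2C[C@H]1C=C(C)[C@H]2C(=O)NCCS(N)(=O)=O`: 4%
- compound 2 `CCOC(=O)[C@H](F)ON1C(=O)N2C[C@H]1C(C)=C[C@H]2C(N)=O`: 71%
- compound 3 `CC1=C[C@@H](C(N)=O)N2C[C@@H]1N(O[C@@H](F)C(=O)OC(C)C)C2=O`: 84%

Compound 2, at 71%, is the second highest of the three numbers in this assay, with compound 3 above it and compound 1 far below it.

The next case is compound 4 `CCOC(=O)[C@@H](F)ON1C(=O)N2C[C@H]1C(C)=C[C@H]2C(N)=O`, set against compound 2. The structural change is the two compounds have the same atoms and bonds and differ only in configuration as drawn: 1 of 3 stereo elements differ; a stereocentre at a saturated chain carbon is drawn S in compound 2 and R in compound 4. Nothing is added or lost, and only the drawn configuration at that saturated chain carbon differs.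

Among the measured compounds shown here, the one measured step between compounds that differ in one place is a number 13 percentage points higher from compound 2 to compound 3 (beyond the scatter). It is a modest step, but it comes from methyl in place of hydrogen, not from a change of configuration, so it bears on this case only loosely, as a guide to the size a single small change has reached in this series. For the measured compounds named here, no measured pair isolates a change of configuration, so the data give no direction for one.

The expected change is small, and the estimated step is a number 5 percentage points lower from compound 2 to compound 4 (within the scatter), with the direction held only weakly and the range kept wide on both sides.

For compound 4 the estimated value is 66%, with an expected range from 40% to 85%.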

Compound 4, oral bioavailability: 75%
The estimate for compound 4 lay 9 percentage points below the measured number; low and high end bracket the measured number.
By their numbers in this assay, from the lowest: compound 1; then compounds 2, 4 and 3 (each within the scatter of the next, the first and the last beyond it).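

The series now holds a measured step for a change of configuration at this saturated chain carbon: in this assay it is a number 4 percentage points higher from compound 2 to compound 4 (within the scatter). Where a number 13 percentage points higher from compound 2 to compound 3 (beyond the scatter) stands beyond the scatter, this step does not, so this read-out gives no ground for separating the S and R drawings at this carbon in this pair. The comparison is a clean one, with one of the three stereo elements changed, nothing added or lost, and the read-out unable to tell the two apart; the result therefore rests on a single change: the fact that compounds 2 and 4 differ only in the configuration as drawn

Among the compounds shown here, only this one pair isolates the configuration at this carbon, so the result cannot be carried over to compounds with other groups on the core, such as compound 3 with its additional methyl, nor to the other two stereo elements, which stay the same in compounds 2 and 4. Also open, going by these compounds, is whether the two drawn configurations would remain indistinguishable in this assay with a carboxylic acid in place of the ester, or with chlorine in place of the fluorine on this carbon.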